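This account rests on a few compounds, and the source may have more. Where it says the series, first, only, none or still open, it means among the compounds named here.

Compound 1 `Cc1cccc(CSc2cc(Cl)c(C)cc2S(=O)(=O)/N=C(\N)n2nccc2-c2ccccc2)c1` gives 8000 nM in a functional assay on HeLa cells (Homo sapiens) for cytotoxicity, read by MTT assay, with a stated time of 72 h; on this read-out lower numbers stand for stronger inhibition and higher numbers for weaker inhibition.
Compound 2 `Cc1cc(S(=O)(=O)/N=C(\N)n2nccc2-c2ccccc2)c(SCc2cccc3ccccc23)cc1Cl` gives 3000 nM in this assay.
Compound 3 `Cc1cc(-c2ccccc2)n(/C(N)=N/S(=O)(=O)c2cc(C)c(Cl)cc2SCc2ccc(Cl)cc2)n1` gives 3000 nM in this assay.

On these three numbers compound 3 stands level with compound 2 at the digits shown, and the two of them together sit lowest of the three, while compound 1 lies higher by a 2.7-fold lower number from compound 1 to compound 2 (0.43 log units; beyond the scatter) measured toward compound 2. For the measured compounds named here, the one step that has been measured, a 2.7-fold lower number from compound 1 to compound 2 (0.43 log units; beyond the scatter), concerns only the group on the saturated chain carbon bound to a sulfur and says nothing about the five-membered ring.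

Compound 4 `Cc1cc(S(=O)(=O)/N=C(\N)n2nccc2-c2ccccc2)c(SCc2ccc(Cl)cc2)cc1Cl` keeps the 4-chlorophenyl of compound 3 and differs from it in one place: hydrogen in place of methyl on an aromatic carbon. Going by the values given here, no measured pair among compounds 1, 2 and 3 changes this position, so there is no step on record to lean on. With nothing to point either way, the expectation for compound 4 in this assay is a step of about no change at the digits printed from compound 3 to compound 4 (within the scatter), that is, no change beyond the scatter. Compound 4 is therefore estimated at 3000 nM, with a range from 1200 nM to 8000 nM.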

Compound 4, half-maximal inhibitory concentration: 3000 nM
The estimate for compound 4 equals the measured number at the digits printed; the range from low to high includes it.
By their numbers in this assay, from the lowest: compounds 2, 3 and 4 (each within the scatter of the next); then compound 1.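

For the compounds shown here, for the first time the carbon of the five-membered aromatic ring that bears methyl in compound 3 is varied, and in this assay hydrogen in place of that methyl gives no change at the digits printed from compound 3 to compound 4 (within the scatter), so with this sulfur-linked 4-chlorophenyl group the methyl can be removed without a shift beyond the scatter. Compound 4 also tests the group on the saturated chain carbon bound to a sulfur with the methyl absent, where 4-chlorophenyl in place of 3-methylphenyl gives a 2.7-fold lower number from compound 1 to compound 4 (0.43 log units; beyond the scatter) and 4-chlorophenyl in place of naphthalen-1-yl gives no change at the digits printed from compound 2 to compound 4 (within the scatter), so the earlier lower number is not confined to naphthalen-1-yl. Nothing available gives a reason for these numbers.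

On these data alone, only methyl and hydrogen are compared on this aromatic carbon, so it remains open whether an ethyl group, an amine or a carboxylic acid there would leave the number unchanged. As far as these compounds go, it is also open whether the phenyl group on the same ring could be replaced by a pyridine ring or a cyclohexyl group, and how either change would read in this assay.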